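The source may report more compounds than this note shows. Statements on the series, on what has been measured and on what is new or still open speak of the compounds shown alone.

Measured compounds:
Compound 1, `Fc1cc(Cl)ccc1-c1ccc(Cn2nnc3ccccc32)cn1`, gives 50 nM in a functional assay on cells for positive allosteric modulation of metabotropic glutamate receptor 2 (Homo sapiens), read by fluorescence and calcium flux, with a stated time of 30 min; a lower number here means that less compound is needed, a higher number that more compound is needed for the effect.
Compound 2, `Fc1cc(Cl)ccc1-c1ccc(Cn2nnc3c(F)cccc32)cn1`, gives 27 nM in this assay.

Compound 2 holds the lowest of the two numbers in this assay; its nearest neighbour is compound 1, and the two lie within the usual scatter of each other, so neither can be called the stronger. Within the data shown here, the only recorded step, a 1.9-fold lower number from compound 1 to compound 2 (0.27 log units; within the scatter), shows how little the number moved when a fluoro group entered at this place. Compound 3, `N#Cc1cccc2c1nnn2Cc1ccc(-c2ccc(Cl)cc2F)nc1`, is not yet measured. It differs from compound 2 by cyano in place of fluoro on an aromatic carbon. Among the measured compounds shown here, no measured compound carries a cyano group, so the single step at this place is the only guide, and it stayed within the scatter. Compound 3 is therefore expected to show a step of a 1.3-fold higher number from compound 2 to compound 3 (0.11 log units; within the scatter), which should not exceed the scatter. Compound 3 is estimated at 35 nM, with a range from 12 nM to 100 nM.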

Compound 3, half-maximal effective concentration: 33 nM
Compound 3: middle estimate off by 1.1-fold (0.03 log units), on the high side; the measured number falls inside the stated range.
By their numbers in this assay, from the lowest: compounds 2, 3 and 1 (each within the scatter of the next).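

In this assay this aromatic carbon has now held hydrogen, fluoro and cyano, and a 1.2-fold higher number from compound 2 to compound 3 (0.09 log units; within the scatter) for the swap of fluoro to cyano, while a 1.5-fold lower number from compound 1 to compound 3 (0.18 log units; within the scatter) for cyano in place of hydrogen. Cyano brings a triple bond and a hydrogen-bond acceptor that fluoro lacks, yet the number stays within the scatter, so the three compounds cannot be put in order and this position tolerates all three without a readable change. No supporting measurement bears on this result.

Still open, on these data alone, is whether an amine, a carboxylic acid or a longer chain at this carbon would move the number beyond the scatter. As far as these compounds go, whether fluoro or cyano would behave the same way on another carbon of this ring also remains unknown.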